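A Benzyl Swap in a Pair of Weak Inhibitors

This account rests on a few compounds, and the source may have more. Where it says the series, first, only, none or still open, it means among the compounds named here.

Compound 1 `C#CCN(CCCCOc1ccc2ccc(=O)oc2c1)Cc1ccc(OC)cc1` was examined in an ADME assay on isolated protein for inhibition of Amine oxidase [flavin-containing] A (Homo sapiens), read by fluorescence and Amplex Red, with stated times of 15 min and 20 min; on this read-out lower numbers stand for stronger inhibition and higher numbers for weaker inhibition. In this assay compound 1 gives 54500 nM. Among the measured compounds shown here, the only other measured compound, compound 2 `C#CCN(CCCOc1ccc2ccc(=O)oc2c1)Cc1ccccc1`, gives 38600 nM in this assay. Compound 1 therefore stands at the higher of the two numbers recorded, yet its distance from compound 2 lies within the scatter of this assay, so the two values cannot be told apart. For the measured compounds named here, no step between two measured compounds that differ in a single place is available here.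

Compound 3 `C#CCN(CCCCOc1ccc2ccc(=O)oc2c1)Cc1ccc(F)c(F)c1` differs from compound 1 in one place: 3,4-difluorophenyl in place of 4-methoxyphenyl on a saturated chain carbon bound to an amine nitrogen. Nothing in the two measured values fixes a direction for this change, and both values sit at the weak end of this assay. The step from compound 1 to compound 3 is therefore expected to be a 1.6-fold lower number from compound 1 to compound 3 (0.19 log units; within the scatter), a modest move that may not exceed the scatter. On that basis compound 3 is estimated at 35000 nM in this assay, with a range from 9000 nM to 140000 nM.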

Compound 3, half-maximal inhibitory concentration: 93200 nM
Beside the measured number, compound 3's estimate is 2.7-fold (0.43 log units) below it; measured number inside the range.
By their numbers in this assay, from the lowest: compounds 2, 1 and 3 (each within the scatter of the next, the first and the last beyond it).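

Among the compounds shown here, the step at this position is the first one available between compounds that differ in a single place, and in this assay it reads a 1.7-fold higher number from compound 1 to compound 3 (0.23 log units; within the scatter). The exchange removes the one hydrogen-bond acceptor counted in 4-methoxyphenyl and brings in two fluorine atoms with 3,4-difluorophenyl, yet compound 1 and compound 3 cannot be told apart, so on a saturated chain carbon bound to an amine nitrogen this pair shows no measurable consequence of the exchange. No measurement available here bears on why the two groups read alike.

One pair cannot show whether this position is insensitive in general, and a group such as 4-hydroxyphenyl or a pyridine ring could still read differently from 4-methoxyphenyl beyond the scatter. Also open, as far as these compounds go, is what a longer chain would do with either benzyl group held fixed, since compound 2 differs from compound 1 and from compound 3 in more than one place and so gives no single-place comparison with either.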